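Removing a Chloro Group: A Small Step Expected

This account rests on a few compounds, and the source may have more. Where it says the series, first, only, none or still open, it means among the compounds named here.

Of the compounds shown here, three have been tested and a fourth awaits measurement. Compound 1 `ClCc1ccc(Cn2cnc3nc(Cl)nc(Cl)c32)cc1`, compound 2 `ClCc1ccccc1Cn1cnc2ncnc(Cl)c21` and compound 3 `ClCc1ccccc1Cn1cnc2nc(Cl)nc(Cl)c21` were examined in a functional assay on NCI-H322M cells (Homo sapiens) for cytotoxicity, read by sulforhodamine B assay, with a stated time of 48 h; on this read-out lower numbers stand for higher toxicity in this test and higher numbers for lower toxicity in this test. In this assay compound 1 gives 4460 nM, compound 2 gives 40700 nM and compound 3 gives 39800 nM.

Compound 2 and compound 3 differ in one place: hydrogen in place of chloro on an aromatic carbon. The measured step, a 1.0-fold higher number from compound 3 to compound 2 (0.01 log units; within the scatter), lies within the usual scatter of repeated measurements, so the two values show no real separation.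

Compound 1 and compound 3 contain the same atoms joined differently; the difference between the two cores is not broken down here. Compound 1 stands at the lowest number of the three, and its distance to each of the others lies beyond the scatter.

Compound 4 `ClCc1ccc(Cn2cnc3ncnc(Cl)c32)cc1` is not yet measured. It arises from compound 1 by hydrogen in place of chloro on an aromatic carbon; the surroundings of the place are described in exactly the same words as for the change from compound 3 to compound 2, so it is the same change. Because a 1.0-fold higher number from compound 3 to compound 2 (0.01 log units; within the scatter) fell within the scatter, the step from compound 1 to compound 4 is expected to be small too, namely a 1.0-fold higher number from compound 1 to compound 4 (0.00 log units; within the scatter). Compound 4 is therefore estimated to give 4500 nM in this assay, with the expected range running from 1800 nM to 11000 nM.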

Compound 4, concentration lethal to 50% of the cells: 5620 nM
For compound 4 the middle estimate is 1.2-fold (0.10 log units) below the measured one, within the range that was stated.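

In this assay, taking away the chloro group that sits between two ring nitrogen atoms and putting hydrogen in its place gives a 1.3-fold higher number from compound 1 to compound 4 (0.10 log units; within the scatter), so this pair, like the earlier one, shows no real separation. Set side by side, the two results agree: the same change on two cores in this assay, a 1.0-fold higher number (0.01 log units; within the scatter) from compound 3 to compound 2 and a 1.3-fold higher number (0.10 log units; within the scatter) from compound 1 to compound 4, 1.2-fold (0.09 log units) apart, within the scatter of two such steps

In these two pairs, then, the change carries from one core to the other and leaves the number within the scatter each time, but two pairs are a small sample, and they show neither why the swap makes so little difference nor whether the same would hold on a further core or in a different test.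

The compounds shown carry only chloro or hydrogen at this place, so what an amine, a methoxy group or a longer chain would do there remains open. From the compounds shown here alone, the chloromethyl group and the second chloro group on the ring are present in all four compounds, so it also remains open what happens when either is replaced, for example by a hydroxymethyl group or an amine.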